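Solubility in a benzyloxy benzamide series: compound 4

A few compounds are considered here, and "the series" means these few. Any claim that something is new, unique, unknown or untested is made for them only; others in the source may bear on it.

Measured so far in a physicochemical assay for solubility, measured as kinetic solubility; a higher number here means a more soluble compound, a lower number a less soluble compound:
- Compound 1 `O=C(Nc1ccnnc1)c1cc(N2CCC(F)CC2)ccc1OCc1ccccc1` gives 20000 nM.
- Compound 2 `CN1CCC(c2ccc(OCc3ccccc3)c(C(=O)Nc3ccnnc3)c2)CC1` gives 71000 nM.
- Compound 3 `CN1CC2(CCN(c3ccc(OCc4ccccc4)c(C(=O)Nc4ccnnc4)c3)CC2)C1` gives 266000 nM.

Compound 3 stands highest of the three in this assay; its nearest neighbour is compound 2, with a 3.7-fold higher number from compound 2 to compound 3 (0.57 log units; beyond the scatter), and the furthest is compound 1, with a 13-fold higher number from compound 1 to compound 3 (1.12 log units; beyond the scatter). Within the measured set, the step of a 3.6-fold higher number from compound 1 to compound 2 (0.55 log units; beyond the scatter) is modest, and both changes away from compound 1 raise the number.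

Compound 4 `N#CC1CCN(c2ccc(OCc3ccccc3)c(C(=O)Nc3ccnnc3)c2)CC1` is the next member. Its change from compound 3 is a group of 8 heavy atoms (6 carbon, 2 nitrogen; one six-membered non-aromatic ring with 1 hetero atom) in place of a group of 10 heavy atoms (8 carbon, 2 nitrogen; one four-membered non-aromatic ring with 1 hetero atom, one six-membered non-aromatic ring with 1 hetero atom), on an aromatic carbon. The step that bears most directly on it is the large one from compound 1 to compound 3, taken in reverse, since the entering group, like that of compound 1, is a single six-membered non-aromatic ring with one hetero atom; the modest step from compound 2 to compound 3 points the same way. A drop in this assay is therefore expected, probably large, giving an estimated 11-fold lower number from compound 3 to compound 4 (1.03 log units; beyond the scatter). For compound 4 the expected value is 25000 nM, with a range of 8000 nM to 80000 nM.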

Compound 4, solubility: < 1000 nM
Compound 4: only a limit was reported; the forecaster's own chance of this, stated with the estimate: 5%; middle value at least 25-fold (1.39 log units) from the limit.
By their numbers in this assay, from the lowest: compound 1; then compound 2; then compound 3. At a limit, below all of these: compound 4.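

In this assay compound 4 gives < 1000 nM as a limit of the assay, not a number: the limit of < 1000 nM in this assay, at which 1 of the 4 values shown sits.
Among these compounds, this is the first change at this position, on an aromatic carbon para to a benzyloxy group, to lower the number, with a large step from each earlier compound (an at least 260-fold lower number from compound 3 to compound 4 (2.42 log units; beyond the scatter); an at least 71-fold lower number from compound 2 to compound 4 (1.85 log units; beyond the scatter)).
The sharpest comparison is cyano in place of fluoro on a saturated ring carbon (an at least 20-fold lower number from compound 1 to compound 4 (1.30 log units; beyond the scatter)), which shows that the substituent on that ring, and not the single six-membered ring alone, can carry a large step.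

Among the compounds shown here, how far the true value of compound 4 lies under its limit remains open, and no property behind the step is measured here.
Also open, on these data alone, is how a primary amine or a carboxylic acid in place of the cyano on that ring carbon would read in this assay.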